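This account rests on a few compounds, and the source may have more. Where it says the series, first, only, none or still open, it means among the compounds named here.

Compound 1, `CCCCCCCCCCCC(=O)N[C@H](CCC(=O)NC(CCCCC(=O)O)C(=O)O)C(=O)O`: > 100 nM 
Compound 2, `CCCCCCCCCCCC(=O)N[C@H](CCC(=O)NCCCCCN)C(=O)O`: > 100 nM 
Compound 3, `CCCCCCCCCCCC(=O)N[C@H](CCC(=O)NC1CCCCNC1=O)C(=O)O`: 1.73 nM 

In a functional assay on HEK293 cells for agonist activity at Nucleotide-binding oligomerization domain-containing protein 1 (Homo sapiens), read by spectrophotometry (a lower number here means that less compound is needed, a higher number that more compound is needed for the effect), compound 3 stands alone with a measured number; the other two values are limits of the assay. For compound 1 the result of > 100 nM is such a limit. For compound 2 the result of > 100 nM is likewise a limit. The step that the two limits leave unreadable from compound 1 to compound 2 is therefore unreadable, while an at least 57-fold lower number from compound 1 to compound 3 (1.76 log units; beyond the scatter) and an at least 57-fold lower number from compound 2 to compound 3 (1.76 log units; beyond the scatter) are both large, the ring-closed compound 3 coming out far ahead of either open chain.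

Compound 4, `CCCCCCCCCCCC(=O)N[C@H](CCC(=O)N[C@H](CCCCN)C(=O)O)C(=O)O`, has not yet been measured. It differs from compound 3 in that (5-amino-1-carboxypentyl in place of 2-oxoazepan-3-yl on an amide-type nitrogen). This opens the ring of compound 3 back into a chain, much as in compound 2, which sits at the limit (the limit of > 100 nM in this assay, at which 2 of the 3 values shown sit), and adds a carboxy group, as compound 1 carries, which also sits at that limit. The two steps that bear on it, an at least 57-fold lower number from compound 2 to compound 3 (1.76 log units; beyond the scatter) and an at least 57-fold lower number from compound 1 to compound 3 (1.76 log units; beyond the scatter), both ran the other way and were large. Compound 4 is therefore expected to give a step of an 87-fold higher number from compound 3 to compound 4 (1.94 log units; beyond the scatter) in this assay, a large rise. The estimate for compound 4 is 150 nM, within 30 nM to 1000 nM, with a good chance that only a limit is reported.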

Compound 4, half-maximal effective concentration: > 100 nM
Compound 4 was reported as a limit (the forecaster's own chance of this, stated with the estimate: 60%); the middle value lies beyond the limit too.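

In this assay compound 4 gives > 100 nM, which is a limit of the assay. Putting a carboxy group on the open chain of compound 2 therefore does not recover a measurable result, and the change of 2-oxoazepan-3-yl to 5-amino-1-carboxypentyl on this amide-type nitrogen gives an at least 57-fold higher number from compound 3 to compound 4 (1.76 log units; beyond the scatter). The steps from compound 1 and from compound 2 to compound 4 cannot be read, and 2-oxoazepan-3-yl remains the only group here with a measured number: the limit of > 100 nM in this assay, at which 3 of the 4 values shown sit.

On these data alone, how far compound 1, compound 2 and compound 4 lie past that limit stays open, so the effect of the carboxy group cannot be sized. Also open, as far as these compounds go, is whether the ring alone or its carbonyl and amide hydrogen matter, a question that a cycloheptyl or 2-oxopiperidin-3-yl group could address.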